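The source may hold more compounds than are shown below. What is called first, only, known or untested is meant among the compounds shown, and "the series" means these compounds.

Working notes on the series. In an assay on isolated protein (Oryctolagus cuniculus) with Thromboxane-A synthase (Homo sapiens) as the target, tested at 1 uM (on this read-out lower numbers stand for less inhibition and higher numbers for more inhibition at the one concentration tested (going by the name of the read-out)), compound 1 `Cn1nc(-c2cccnc2)c2ccccc2c1=O` gives 63%, compound 2 `CCCn1nc(-c2cccnc2)c2ccccc2c1=O` gives 86% and compound 3 `C=CCn1nc(-c2cccnc2)c2ccccc2c1=O` gives 70%. Compound 3 thus stands second highest of the three, within the scatter of compound 1 and beyond it against compound 2. The measured steps read a number 23 percentage points higher from compound 1 to compound 2 (beyond the scatter) (modest), a number 7 percentage points higher from compound 1 to compound 3 (within the scatter) (within the scatter) and a number 16 percentage points lower from compound 2 to compound 3 (beyond the scatter) (modest). Compound 4 `O=c1c2ccccc2c(-c2cccnc2)nn1Cc1ccccc1` differs from compound 3 by phenyl in place of vinyl on a saturated chain carbon bound to an aromatic nitrogen, cut one bond further out allyl to benzyl. The two modest steps involving compound 2 bear on it; on that basis a modest rise, or none beyond the scatter, is expected in this assay. For compound 4 the expected step is a number 8 percentage points higher from compound 3 to compound 4 (within the scatter). Compound 4 is estimated at 78%, between 62% and 92%.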

Compound 4, a percentage reported as inhibition, at one concentration (the size of the read-out at that concentration, not a potency): 97%
Beside the measured number, compound 4's estimate is 19 percentage points below it, outside the stated range (above it).
By their numbers in this assay, from the lowest: compounds 1 and 3 (each within the scatter of the next); then compound 2; then compound 4.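

In this assay phenyl on the saturated chain carbon bound to an aromatic nitrogen goes beyond every earlier group, with a number 27 percentage points higher from compound 3 to compound 4 (beyond the scatter) and a number 11 percentage points higher from compound 2 to compound 4 (beyond the scatter) and a number 34 percentage points higher from compound 1 to compound 4 (beyond the scatter) at this position. This place therefore accepts a six-membered aromatic ring of carbon only, and compound 4 stands highest of the four, beyond the scatter against each of the others. No measurement at hand gives a reason for this rise.

Left open is whether a longer chain such as butyl would match phenyl here, and whether a phenyl carrying an amine or a carboxylic acid would hold the level of compound 4.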